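The source may report more compounds than this note shows. Statements on the series, on what has been measured and on what is new or still open speak of the compounds shown alone.

Measured in a physicochemical assay, with a stated time of 6 min; a higher number here means a weaker inhibitor, a lower number a stronger inhibitor:
- Compound 1 `COc1ccc(NC(=O)Nc2nc(-c3cc4ccccc4o3)cs2)cc1`: 17400 nM
- Compound 2 `O=C(Nc1ccc([N+](=O)[O-])cc1)Nc1nc(-c2cc3cc(Br)ccc3o2)cs1`: > 200000 nM, a limit and not a number

Compound 2 has no exact number in this assay, only (the limit of > 200000 nM in this assay, at which 1 of the 2 values shown sits). Compound 3 `O=C(Nc1nc(-c2cc3cc(Br)ccc3o2)cs1)Nc1ccccc1[N+](=O)[O-]` carries 2-nitrophenyl in place of 4-nitrophenyl on an amide-type nitrogen. Going by the values given here, no measured pair shows what such a change does, and the only exact number is that of compound 1 at 17400 nM. As far as these compounds go, the estimated step of an at least 2.2-fold lower number from compound 2 to compound 3 (0.34 log units; beyond the scatter) is expected to be modest, towards a stronger inhibitor, and its size remains open. Compound 3 is expected at 90000 nM, with an estimated range of 20000 nM to 200000 nM.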

Compound 3, half-maximal inhibitory concentration: 166000 nM
Beside the measured number, compound 3's estimate is 1.8-fold (0.27 log units) below it; the range from low to high includes it.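

With 2-nitrophenyl on the amide-type nitrogen, compound 3 gives an exact number in this assay, 166000 nM, which compound 2 with 4-nitrophenyl does not. The change amounts to an at least 1.2-fold lower number from compound 2 to compound 3 (0.08 log units; that floor lies within the scatter), so no real gain is shown. The true size of the step stays unknown, as it rests on a limit: the limit of > 200000 nM in this assay, at which 1 of the 3 values shown sits.

Open remains how an amine or a carboxylic acid in place of the nitro group would read on this phenyl ring. No pair shown differs in the bromine alone, so its share also stays open.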